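The source may hold more compounds than are shown below. What is called first, only, known or untested is meant among the compounds shown, and "the series" means these compounds.

Working notes on the sulfonamide series.

Compound 1 `O=S(=O)(Nc1ccc(-c2nc3ccccc3o2)cc1)c1ccc(F)c(C(F)(F)F)c1` is followed here across the step to compound 4 `O=S(=O)(Nc1ccc(-c2nc3ccccc3o2)cc1)c1ccc(Cl)c(C(F)(F)F)c1` in an assay on isolated protein for inhibition of malate dehydrogenase, mitochondrial (Sus scrofa), with stated times of 45 min and 30 min; on this read-out higher numbers stand for weaker inhibition and lower numbers for stronger inhibition. For compound 1 the result is a limit of the assay, not a number: compound 1 gives > 63000 nM. Compound 2 `O=S(=O)(Nc1ccc2oc(-c3ccccc3)nc2c1)c1ccc(Cl)c(Cl)c1` likewise reaches only a limit, giving > 63000 nM in this assay. Compound 3 `C=Cc1ccc(S(=O)(=O)Nc2ccc(-c3nc4ccccc4o3)cc2)cc1` also sits at a limit, with > 63000 nM in this assay. Among the compounds with values here, compound 1 therefore stands with the others, all at the limit of > 63000 nM in this assay, at which 3 of the 3 values shown sit, and no measured step between any two of them is available.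

The change from compound 1 to compound 4 is chloro in place of fluoro on an aromatic carbon; chloro in place of fluoro on an aromatic carbon. Within the data shown here, no step of this kind is measured. With compound 1 at > 63000 nM, a step in this assay of no size beyond the scatter is expected, and compound 4 is expected to remain at the limit as well. The estimated step that the limit leaves unreadable from compound 1 to compound 4 is expected to be nominal only. Compound 4 is estimated at 100000 nM, with a range of 40000 nM to 300000 nM.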

Compound 4, half-maximal inhibitory concentration: > 63000 nM
Compound 4: only a limit was reported; the forecaster's own chance of this, stated with the estimate: 85%; the middle value is on the limit's open side.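

Within the data shown here, compound 4, like compound 1, reaches only a limit in this assay, so no step between the two can be read: the limit of > 63000 nM in this assay, at which 4 of the 4 values shown sit. The compounds shown leave open which structural change, if any, would give a readable value in this assay.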